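A few compounds are considered here, and "the series" means these few. Any claim that something is new, unique, unknown or untested is made for them only; others in the source may bear on it.

In an ADME assay on NIH3T3 cells (Mus musculus) for cytotoxicity, read by MTT assay (on this read-out lower numbers stand for stronger inhibition and higher numbers for weaker inhibition), compound 1 `N#Cc1c(-c2ccccc2)c(C#N)c(=O)n(/N=C/c2cn(-c3ccccc3)nc2-c2ccccc2)c1N` gives 180 ug/mL. Compound 2 `N#Cc1c(-c2ccccc2O)c(C#N)c(=O)n(/N=C/c2cn(-c3ccccc3)nc2-c2ccccc2)c1N` gives 162 ug/mL, and compound 1 is its only neighbor here, the step of a 1.1-fold lower number from compound 1 to compound 2 (0.05 log units; within the scatter) lying within the scatter. Compound 3 `N#Cc1c(-c2ccc(Cl)cc2)c(C#N)c(=O)n(/N=C/c2cn(-c3ccccc3)nc2-c2ccccc2)c1N` differs from compound 2 in one place: 4-chlorophenyl in place of 2-hydroxyphenyl on an aromatic carbon. For the measured compounds named here, the only measured step that bears on this change is the one from compound 1 to compound 2, and it stayed within the scatter, so no shift beyond the scatter is expected in this assay. Compound 3 is therefore estimated at 160 ug/mL, in a range from 90 ug/mL to 290 ug/mL. The expected step is a 1.0-fold lower number from compound 2 to compound 3 (0.01 log units; within the scatter).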

Compound 3, half-maximal inhibitory concentration: 64 ug/mL
The estimate for compound 3 lay 2.5-fold (0.40 log units) above the measured number, outside the stated range (below it).
By their numbers in this assay, from the lowest: compound 3; then compounds 2 and 1 (each within the scatter of the next).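

At this position, opposite the ring nitrogen, a change of the aryl group can move the number in this assay beyond the scatter: there is a 2.5-fold lower number from compound 2 to compound 3 (0.40 log units; beyond the scatter) and also a 2.8-fold lower number from compound 1 to compound 3 (0.45 log units; beyond the scatter). Adding chloro thus did what adding hydroxy had not, shifting the read-out towards stronger inhibition. Nothing available explains this shift.

Going by these compounds, whether the shift depends on where chloro sits on the phenyl ring stays open. So does whether a bromo, a methoxy or an amine on that ring would also lower the number.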